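From pyridin-2-yl to 2-fluorophenyl at an assay limit

The compounds below may be only part of what the source reports. "The series", "measured", "known", "first", "only" and "open" are said of these compounds alone.

In an ADME assay on HepG2 cells (Homo sapiens) for cytotoxicity, in the presence of a further agent that is not named here (on this read-out higher numbers stand for weaker inhibition and lower numbers for stronger inhibition), compound 3 (`Cn1c(Cc2ccccc2C(F)(F)F)nc(C(=O)NCc2ccccn2)c(O)c1=O`) reads > 100000 nM as a limit of the assay, not as a number. Compound 1 (`Cn1c(Cc2ccccc2C(F)(F)F)nc(C(=O)NCc2cccnc2)c(O)c1=O`) likewise reads > 100000 nM as a limit. Compound 2 (`Cn1c(Cc2ccccc2C(F)(F)F)nc(C(=O)NCC2CCCCC2)c(O)c1=O`) also reads > 100000 nM as a limit.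

Compound 4 (`Cn1c(Cc2ccccc2C(F)(F)F)nc(C(=O)NCc2ccccc2F)c(O)c1=O`) has not yet been measured. It carries 2-fluorophenyl in place of the pyridin-2-yl of compound 3, on a saturated chain carbon bound to an amide-type nitrogen (2-fluorophenyl in place of pyridin-2-yl on a saturated chain carbon bound to an amide-type nitrogen). Two measured changes at this same place bear on it: a step that the two limits leave unreadable from compound 1 to compound 3 and also a step that the two limits leave unreadable from compound 2 to compound 3 and neither has a readable size.

All three measured compounds sit at the limit of > 100000 nM in this assay, at which 3 of the 3 values shown sit, so no step beyond the scatter is expected in this assay and no direction can be favoured. Compound 4 will probably be reported as a limit too. Put as a number, a number no higher from compound 3 to compound 4 (the limit leaves the size open) is the estimated step. For compound 4 the estimated value is 100000 nM within an expected range of 50000 nM to 200000 nM as a rough guide.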

Compound 4, half-maximal inhibitory concentration: > 100000 nM
Compound 4 ended at the assay's limit; the forecaster's own chance of this, stated with the estimate: 85%; the middle value lies on the limit itself.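

In this assay compound 4 reads > 100000 nM as a limit of the assay, not a number. Within the data shown here, no step between compound 4 and compound 1, compound 2 or compound 3 can be read, because all four stand at one limit: the limit of > 100000 nM in this assay, at which 4 of the 4 values shown sit.

The compounds shown leave open how much the group on the saturated chain carbon changes cytotoxicity, if it changes it at all.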